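This account rests on a few compounds, and the source may have more. Where it says the series, first, only, none or still open, it means among the compounds named here.

Measured in a functional assay on MIA PaCa-2 cells (Homo sapiens) for cytotoxicity, read by MTT assay, with a stated time of 48 h; on this read-out lower numbers stand for stronger inhibition and higher numbers for weaker inhibition:
compound 1, `COc1ccc(-c2nc(-c3c[nH]c4ccccc34)co2)cc1OC`, 103000 nM
compound 2, `Oc1ccc(-c2nc(-c3c[nH]c4ccccc34)co2)cc1`, 103000 nM
compound 3, `C(=C/c1nc(-c2c[nH]c3ccccc23)co1)\c1ccccc1`, 873000 nM

Compound 2 stands level with compound 1 at the digits shown, the two together at the low end of the three numbers; its nearest neighbour is compound 1, its furthest compound 3, whose number lies beyond the scatter above that of compound 2. Compound 4, `C=Cc1nc(-c2c[nH]c3ccccc23)co1`, is not yet measured; it differs from compound 2 by vinyl in place of 4-hydroxyphenyl on an aromatic carbon. Among the measured compounds shown here, no step between measured compounds covers this change; the only point of reference is compound 3, which also lacks the 4-hydroxyphenyl and returns the highest number of the set. For compound 4 a rise beyond the scatter is expected, a 3.9-fold higher number from compound 2 to compound 4 (0.59 log units; beyond the scatter). Compound 4 is thus estimated at 400000 nM, in the range 150000 nM to 1500000 nM.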

Compound 4, half-maximal inhibitory concentration: 37600 nM
The estimate for compound 4 lay 11-fold (1.03 log units) above the measured number; measured number outside the range, below it.
By their numbers in this assay, from the lowest: compound 4; then compounds 1 and 2 (each within the scatter of the next); then compound 3.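

In this assay vinyl in place of 4-hydroxyphenyl on this aromatic carbon gives a 2.7-fold lower number from compound 2 to compound 4 (0.44 log units; beyond the scatter) and so the step is modest but beyond the scatter. A six-membered aromatic ring at this position is therefore not needed to hold the number, at least in this pair, and the smaller group with no hydrogen-bond donor does better. No measured evidence bears on the reason for this shift.

Going by these compounds, whether the double bond itself matters stays open, since ethyl at this carbon would be the direct test. An amine or a carboxylic acid in the same place is equally unresolved.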